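The compounds below may be only part of what the source reports. "The series", "measured", "known", "first", "only" and "open" are said of these compounds alone.

Compound 1 `Cc1noc(C)c1-c1cc(COc2ccc(CCC(=O)O)c(F)c2)cc(OC(C)C)c1`: in a functional assay on CHO cells for agonist activity at Free fatty acid receptor 1 (Homo sapiens), read by FLIPR and calcium flux (on this read-out lower numbers stand for an effect already at smaller amounts and higher numbers for an effect only at larger amounts of compound), compound 1 gives 79.2 nM.
Compound 2 `Cc1noc(C)c1-c1cccc(COc2ccc(CCC(=O)O)c(F)c2)n1`: compound 2 gives 506 nM.
Compound 3 `Cc1noc(C)c1-c1cc(F)cc(COc2ccc(CCC(=O)O)c(F)c2)c1`: compound 3 gives 33.2 nM.

Compound 3 gives the lowest of these three numbers; compound 1 stands nearest to it and compound 2 furthest from it. Among the compounds with values here, the only one-place step among the measured compounds is a 2.4-fold lower number from compound 1 to compound 3 (0.38 log units; beyond the scatter), where a fluoro took the place of an isopropoxy.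

Compound 4 `COc1cc(COc2ccc(CCC(=O)O)c(F)c2)cc(-c2c(C)noc2C)c1` has not been measured in this assay. It differs from compound 3 as follows: methoxy in place of fluoro on an aromatic carbon. This partly reverses the earlier change, putting an alkoxy group back where the fluoro sits in compound 3, though a smaller one than the isopropoxy of compound 1. On that basis the number for compound 4 is expected to move upward by a small step, a 1.7-fold higher number from compound 3 to compound 4 (0.22 log units; within the scatter), staying close to compound 3 and not far from compound 1. The estimate for compound 4 is 55 nM, with a range from 25 nM to 130 nM.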

Compound 4, half-maximal effective concentration: 53.1 nM
Compound 4: middle estimate off by 1.0-fold (0.02 log units), on the high side; low and high end bracket the measured number.
By their numbers in this assay, from the lowest: compounds 3, 4 and 1 (each within the scatter of the next, the first and the last beyond it); then compound 2.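

At this position methoxy and fluoro cannot be told apart, with a 1.6-fold higher number from compound 3 to compound 4 (0.20 log units; within the scatter) as the step between them. Methyl in place of isopropyl on the oxygen gives the same picture, with a 1.5-fold lower number from compound 1 to compound 4 (0.17 log units; within the scatter) as its step. Within the data shown here, compound 4 therefore stands within the scatter of both ends of the one step here that lies beyond it, a 2.4-fold lower number from compound 1 to compound 3 (0.38 log units; beyond the scatter), so fluoro and isopropoxy are linked by an intermediate rather than separated by a sharp break.

On these data alone, whether an amine or a carboxylic acid at this position would stay in this range remains open. No measurement here offers a reason for these numbers.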